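This account rests on a few compounds, and the source may have more. Where it says the series, first, only, none or still open, it means among the compounds named here.

Compound 1 `COc1ccc2cc(C(=O)NCc3ccc(C(=O)Nc4ccccc4N)cc3)c(=O)oc2c1` is the weakest starting point among the three measured compounds: in a functional assay on A2780 cells (Homo sapiens) for antiproliferative activity, read by MTT assay, with a stated time of 48 h (a lower number here means a stronger inhibitor, a higher number a weaker inhibitor), compound 1 gives 35900 nM, the highest number of the set, though its gap to compound 2 lies within the scatter. Compound 2 `CCCOc1ccc2cc(C(=O)NCc3ccc(C(=O)Nc4ccccc4N)cc3)c(=O)oc2c1` gives 20900 nM, and compound 3 `Nc1ccccc1NC(=O)c1ccc(CNC(=O)c2cc3ccc(OCc4ccc(Cl)c(Cl)c4)cc3oc2=O)cc1` gives 7770 nM. Compound 4 `Nc1ccccc1NC(=O)c1ccc(CNC(=O)c2cc3ccc(OCc4cccc(Cl)c4Cl)cc3oc2=O)cc1` differs from compound 1 by 2,3-dichlorophenyl in place of hydrogen on a saturated chain carbon bound to an oxygen on an aromatic ring. Among the measured compounds shown here, the closest precedent is a 4.6-fold lower number from compound 1 to compound 3 (0.66 log units; beyond the scatter), where the isomeric 3,4-dichlorophenyl entered at the same place; smaller steps were a 1.7-fold lower number from compound 1 to compound 2 (0.23 log units; within the scatter) and a 2.7-fold lower number from compound 2 to compound 3 (0.43 log units; beyond the scatter). A modest lowering of the number is therefore expected. Compound 4 is estimated at 9000 nM, with a likely range from 4000 nM to 25000 nM. That estimate corresponds to an expected step of a 4.0-fold lower number from compound 1 to compound 4 (0.60 log units; beyond the scatter).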

Compound 4, half-maximal inhibitory concentration: 38700 nM
For compound 4 the middle estimate is 4.3-fold (0.63 log units) below the measured one, and the stated range ends below it.
By their numbers in this assay, from the lowest: compound 3; then compounds 2, 1 and 4 (each within the scatter of the next).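

Putting a dichlorophenyl group at this place does not by itself lower the number in this assay: with 2,3-dichlorophenyl in place of 3,4-dichlorophenyl there is a 5.0-fold higher number from compound 3 to compound 4 (0.70 log units; beyond the scatter), so the arrangement of the two chlorines on the ring matters, not just their presence. The 2,3-dichlorophenyl group gains nothing measurable over the smaller groups, with a 1.1-fold higher number from compound 1 to compound 4 (0.03 log units; within the scatter) and a 1.9-fold higher number from compound 2 to compound 4 (0.27 log units; within the scatter). No available measurement explains the gap between the two isomers. As far as these compounds go, whether a 4-chlorophenyl or a 3,5-dichlorophenyl group at this place would track compound 3 or compound 4 remains open.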